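Testing a Second Carboxy Group on the Amide Nitrogen

The compounds below may be only part of what the source reports. "The series", "measured", "known", "first", "only" and "open" are said of these compounds alone.

Compound 1 `CCn1c(C(=O)NC(C)(C)CO)ccc1C(CC)(CC)c1ccc(OCS(=O)(=O)c2ccccc2)c(C)c1`: 9850 nM
Compound 2 `CCn1c(C(=O)N[C@H](C(=O)O)C(C)C)ccc1C(CC)(CC)c1ccc(OCS(=O)(=O)c2ccccc2)c(C)c1`: 3650 nM

Both compounds were tested in a functional assay on PC-3 cells (Homo sapiens) for antiproliferative activity, read by MTT assay, with a stated time of 24 h; a lower number here means a stronger inhibitor, a higher number a weaker inhibitor. Compound 2, at 3650 nM, has the lower number of the pair, making it the stronger inhibitor so far. The next compound to be tested is compound 3 `CCn1c(C(=O)N[C@H](CC(=O)O)C(=O)O)ccc1C(CC)(CC)c1ccc(OCS(=O)(=O)c2ccccc2)c(C)c1`, which keeps the same core and changes only the group on the amide-type nitrogen: 1,2-dicarboxyethyl in place of 1-carboxy-2-methylpropyl on an amide-type nitrogen. In short, 1,2-dicarboxyethyl replaces 1-carboxy-2-methylpropyl, and neither group contains a ring.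

Among the compounds with values here, only one measured step bears on this change, as it alters the same place: a 2.7-fold lower number from compound 1 to compound 2 (0.43 log units; beyond the scatter). That step was modest, and a single step cannot set a direction for a different group. A large move is therefore not expected, and the change may well stay within the usual scatter. A slight drift to a higher number seems more likely than a further drop, since compound 2 at 3650 nM is the lowest value seen so far. The estimated change is a 1.4-fold higher number from compound 2 to compound 3 (0.14 log units; within the scatter). For compound 3, the expected value is 5000 nM, with an estimated range of 1800 nM to 14000 nM.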

Compound 3, half-maximal inhibitory concentration: > 50000 nM
Compound 3: no number, only a limit (the forecaster's own chance of this, stated with the estimate: 10%); at least 10-fold (1.00 log units) between middle value and limit.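

In this assay compound 3 gives only a limit, not a number: the limit of > 50000 nM in this assay, at which 1 of the 3 values shown sits. The change to 1,2-dicarboxyethyl produces an at least 13-fold higher number from compound 2 to compound 3 (1.13 log units; beyond the scatter), a much larger move than the modest one seen earlier, a 2.7-fold lower number from compound 1 to compound 2 (0.43 log units; beyond the scatter), so this position on the amide-type nitrogen responds far more strongly than the first pair alone could show. The new group also falls behind 1-(hydroxymethyl)-1-methylethyl, an at least 5.0-fold higher number from compound 1 to compound 3 (0.70 log units; beyond the scatter), so a carboxy group alone does not set the order here: compound 2 and compound 3 both carry one, yet they lie on opposite sides of compound 1.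

This single change removes the 2-methylpropyl part and adds a second carboxy group together, so the compounds shown cannot separate the two contributions to the loss. Also open, on these data alone, is whether a methyl ester or a primary amide in place of the second carboxy group, or a longer chain such as 1,3-dicarboxypropyl, would bring the number back towards that of compound 2.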